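From a Benzylamide to a Methyl Ester on a Shared Core

A few compounds are considered here, and "the series" means these few. Any claim that something is new, unique, unknown or untested is made for them only; others in the source may bear on it.

Three compounds were prepared, and only one of them returned a number. Compound 1 `N[C@H]1CC[C@H](Nc2c(C(=O)NCc3ccc(F)cc3)nc(N3CCCCC3)c3cccnc23)CC1` was tested in a functional assay on MCF7 cells (Homo sapiens) for cytotoxicity, read by MTT assay, with a stated time of 72 h (a higher number here means a weaker inhibitor, a lower number a stronger inhibitor), where compound 1 gives 5000 nM. Compound 2 `COc1cccc(CNC(=O)c2nc(Br)c3cccnc3c2N[C@H]2CC[C@H](N)CC2)c1` shares the core of compound 1 but differs from it in more than one place, and in this assay compound 2 gives "not determined" (no result reported), so no number stands for it. Compound 3 `C[C@@H](Nc1c(C(=O)NCc2ccc(F)cc2)nc(Br)c2cccnc12)c1ccccc1` likewise gives "not determined" (no result reported) in this assay. For the measured compounds named here, with no pair of measured neighbours, no step size can be read off at all.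

Compound 4 `COC(=O)c1nc(Br)c2cccnc2c1N[C@H]1CC[C@H](N)CC1` has not yet been measured. It differs from compound 2 by a single change: methoxy in place of (3-methoxybenzyl)amino on a carbonyl carbon. The whole benzylamine portion with its ring leaves, and a small ester remains. Going by the values given here, since compound 1, the only compound with a number, still carries the full benzylamide, the change in compound 4 is expected to move this assay toward weaker inhibition by more than the scatter. Compound 4 is expected to give about 20000 nM, with a likely range from 5000 nM to 80000 nM.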

Compound 4, half-maximal inhibitory concentration: > 20000 nM
Compound 4: only a limit was reported; the forecaster's own chance of this, stated with the estimate: 40%; the middle value lies on the limit itself.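

In this assay compound 4 gives > 20000 nM, which is a limit and not a number. For the compounds shown here, no single number stands for compound 2, so no step from it to compound 4 can be read. The compounds shown leave open how far methoxy in place of (3-methoxybenzyl)amino shifts this read-out.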